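A Limit That Leaves the Next Step Open

The source may hold more compounds than are shown below. What is called first, only, known or untested is meant among the compounds shown, and "the series" means these compounds.

Compound 1 `CCC(=O)Nc1ccc(C(=O)Nc2ccc(C)c(Nc3nccc(-c4cccnc4)n3)c2)cc1` gives > 10000 nM in an ADME assay on BaF3 cells (Mus musculus) for cytotoxicity, read by CellTiter-Glo and CCK-8 assay, with a stated time of 72 h (a higher number here means a weaker inhibitor of growth, a lower number a stronger inhibitor of growth), as a limit. Compound 2 `Cc1ccc(NC(=O)c2ccc(CNCCN(C)C)cc2)cc1Nc1nccc(-c2cccnc2)n1` gives > 10000 nM as a limit too. Compound 3 `C/C=C/C(=O)N(CCN(C)C)Cc1ccc(C(=O)Nc2ccc(C)c(Nc3nccc(-c4cccnc4)n3)c2)cc1` gives > 10000 nM as a limit as well. The three compounds stand together on the limit of > 10000 nM in this assay, at which 3 of the 3 values shown sit, and cannot be ranked.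

Compound 4 `C=CC(=O)N(CCC(C)C)Cc1ccc(C(=O)Nc2ccc(C)c(Nc3nccc(-c4cccnc4)n3)c2)cc1` differs from compound 3 by isopentyl(vinylcarbonyl)amino in place of (2-(dimethylamino)ethyl)((prop-1-en-1-yl)carbonyl)amino on a saturated chain carbon bound to an aromatic carbon on a saturated chain carbon bound to an aromatic carbon. The measured steps nearest this change are a step that the two limits leave unreadable from compound 2 to compound 3 and a step that the two limits leave unreadable from compound 1 to compound 3 alongside a step that the two limits leave unreadable from compound 1 to compound 2 and none gives a size. No step beyond the scatter is therefore expected, and no direction: the expected change is a number no higher from compound 3 to compound 4 (the limit leaves the size open) in this assay for now. Compound 4 is estimated at 10000 nM with an expected range from 3000 nM to 30000 nM around it.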

Compound 4, concentration for 50% growth inhibition: 5620 nM
The estimate for compound 4 lay 1.8-fold (0.25 log units) above the measured number; low and high end bracket the measured number.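

Among the four compounds shown, only compound 4 gives a number rather than a limit in this assay: the limit of > 10000 nM in this assay, at which 3 of the 4 values shown sit. The change reads as an at least 1.7-fold lower number from compound 3 to compound 4 (0.25 log units; that floor lies within the scatter), as an at least 1.7-fold lower number from compound 2 to compound 4 (0.25 log units; that floor lies within the scatter) and as an at least 1.7-fold lower number from compound 1 to compound 4 (0.25 log units; that floor lies within the scatter). Going by these compounds, all three are floors, so isopentyl(vinylcarbonyl)amino on a saturated chain carbon bound to an aromatic carbon gives a lower number, but its true size stays unknown.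

The compounds shown do not separate the isopentyl chain from the vinylcarbonyl. Also open, on these data alone, is what a propanoyl on that nitrogen, or a cyclohexyl in place of isopentyl, would give.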